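Replacing 4-methoxyphenyl with cyclohexyl on the shared core

The source may hold more compounds than are shown below. What is called first, only, known or untested is meant among the compounds shown, and "the series" means these compounds.

In an ADME assay for permeability, using PAMPA, with a stated time of 30 min, at pH 7.4 (on this read-out lower numbers stand for lower permeability and higher numbers for higher permeability), compound 1 `COc1cccc(Oc2ccc3c(NCCCNCc4ccco4)ccnc3c2)c1` gives 317 10^-6 cm/s and compound 2 `CC(C)CCc1ccc2c(NCCCNCc3ccco3)ccnc2c1` gives 23 10^-6 cm/s. Compound 3 `COc1ccc(-c2ccc3c(NCCCNCc4ccco4)ccnc3c2)cc1` gives 237 10^-6 cm/s. Its nearest neighbour lies within the scatter, a 1.3-fold lower number from compound 1 to compound 3 (0.13 log units; within the scatter), while the isopentyl analogue lies far off, a 10-fold higher number from compound 2 to compound 3 (1.01 log units; beyond the scatter). Compound 4 `c1coc(CNCCCNc2ccnc3cc(C4CCCCC4)ccc23)c1` carries cyclohexyl in place of 4-methoxyphenyl on an aromatic carbon. Only compound 2 offers a substituent without an aromatic ring, so the large step of a 14-fold lower number from compound 1 to compound 2 (1.14 log units; beyond the scatter) is the closest guide. Cyclohexyl is not isopentyl, however, so only part of that drop is expected, and the estimated change is a 3.4-fold lower number from compound 3 to compound 4 (0.53 log units; beyond the scatter). Compound 4 is estimated at 70 10^-6 cm/s, with an expected range of 20 10^-6 cm/s to 240 10^-6 cm/s.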

Compound 4, apparent permeability: 23 10^-6 cm/s
Estimate against measurement, compound 4: 3.0-fold (0.48 log units) above, and the stated range covers the measured number.
By their numbers in this assay, from the lowest: compounds 2 and 4 (each within the scatter of the next); then compounds 3 and 1 (each within the scatter of the next).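

Cyclohexyl falls well short of the aromatic substituents, with a 10-fold lower number from compound 3 to compound 4 (1.01 log units; beyond the scatter) and a 14-fold lower number from compound 1 to compound 4 (1.14 log units; beyond the scatter). Among the compounds shown here, a non-aromatic ring offers no gain over the open chain of isopentyl, with no change at the digits printed from compound 2 to compound 4 (within the scatter), so at this position the two substituents with an aromatic ring stand apart from the two without one, and no compound here goes against that split. Nothing shown gives a reason for this split. As far as these compounds go, whether any aromatic ring suffices stays open, as a pyridyl group would test, and so does the effect of a piperidine ring in place of cyclohexyl.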